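A sulfonyl swap on an inactive compound

The source may hold more compounds than are shown below. What is called first, only, known or untested is meant among the compounds shown, and "the series" means these compounds.

Compound 1 `N#C/C(=C\c1ccccc1OS(=O)(=O)c1ccc(Cl)cc1)C(=O)Nc1nnc(Cc2ccc(Cl)cc2)s1`: 64%
Compound 2 `Cc1ccc(Cc2nnc(NC(=O)/C(C#N)=C/c3ccccc3OS(=O)(=O)c3ccccc3[N+](=O)[O-])s2)cc1`: "not active" (no number reported)

Both compounds were tested in a functional assay on RS4-11 cells (Homo sapiens) for inhibition, read by CCK-8 assay, with a stated time of 48 h, tested at 20 uM (on this read-out lower numbers stand for less inhibition of growth and higher numbers for more inhibition of growth at the one concentration tested), and the two results differ in kind. Compound 1 gives 64% of inhibition, a clear number. Compound 2 is reported only as "not active" (no number reported) with no number attached, so it stands at the low end of the pair without an exact position.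

Compound 3 `Cc1ccc(Cc2nnc(NC(=O)/C(C#N)=C/c3ccccc3OS(=O)(=O)c3ccc(Cl)cc3)s2)cc1` has not yet been measured. The structural change is 4-chlorophenyl in place of 2-nitrophenyl on a sulfonyl sulfur and it puts 4-chlorophenyl in place of 2-nitrophenyl on a sulfonyl sulfur.

With no number for compound 2, the size of this step cannot be calculated. The expected direction is towards more inhibition of growth in this assay and by more than the usual scatter. For the measured compounds named here, the only guide is compound 1 at 64% which also carries the (4-chlorophenyl)sulfonyl group, although it is not identical to compound 3 elsewhere in the structure. The estimate is therefore broad. For compound 3 the expected value is 55% (30% to 80%).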

Compound 3, percent growth inhibition at one concentration: 72%
For compound 3 the middle estimate is 17 percentage points below the measured one, and the stated range covers the measured number.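

In this assay, compound 2, with its (2-nitrophenyl)sulfonyl group, gives "not active" (no number reported), while compound 3, with (4-chlorophenyl)sulfonyl on the same sulfonyl sulfur, gives 72%, so in this pair a change at this one place separates an inactive compound from an active one. The size of that step cannot be read, since one side of the pair has no number. With (4-chlorophenyl)sulfonyl in place, methyl in place of chloro on an aromatic carbon gives a number 8 percentage points higher from compound 1 to compound 3 (within the scatter), so this pair shows that swap making no clear difference to the read-out.

Nothing measured here explains why the two sulfonyl groups give such different results. Going by these compounds, it also stays open whether the outcome follows from removing the nitro group, from adding the chlorine, or from both, and whether a plain phenyl ring or a small methyl group on the sulfonyl sulfur would keep the growth inhibition seen with 4-chlorophenyl.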